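Removing the imidazole from a chalcone: an expected step

This account rests on a few compounds, and the source may have more. Where it says the series, first, only, none or still open, it means among the compounds named here.

Three measured compounds share one core and differ only in the ring attached to the carbonyl. Compound 1 `COc1cc(OC)c(OC)cc1/C=C/C(=O)c1cc(Cl)ccc1O` carries a chloro and a hydroxy there; in a functional assay on HeLa cells (Homo sapiens) for inhibition, read by MTT assay, with a stated time of 72 h (on this read-out higher numbers stand for weaker inhibition and lower numbers for stronger inhibition), compound 1 gives > 150000 nM, which is a limit of the assay, not a number. Compound 2 `COc1cc(OC)c(OC)cc1/C=C/C(=O)c1ccc([N+](=O)[O-])cc1` carries a nitro, and in this assay compound 2 gives > 150000 nM, again a limit. Compound 3 `COc1cc(OC)c(OC)cc1/C=C/C(=O)c1ccc(-c2c[nH]cn2)cc1` carries a 1H-imidazol-4-yl, and in this assay compound 3 gives > 150000 nM, once more a limit. The step that the two limits leave unreadable from compound 2 to compound 3 is therefore unreadable, and compound 3 stands where every measured value stands, at the same limit (the limit of > 150000 nM in this assay, at which 3 of the 3 values shown sit). Compound 4 `COc1cc(OC)c(OC)cc1/C=C/C(=O)c1ccccc1` differs from compound 3 by hydrogen in place of 1H-imidazol-4-yl on an aromatic carbon. Among the compounds with values here, no measured step bears on this change with a readable size, so no step beyond the scatter is expected in this assay in either direction. For compound 4 the expected value is 150000 nM, with a range from 30000 nM to 500000 nM. The expected step of a number no higher from compound 3 to compound 4 (the limit leaves the size open) is thus essentially flat, most likely ending at the same limit.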

Compound 4, half-maximal inhibitory concentration: > 150000 nM
Compound 4 gave a limit, no number (the forecaster's own chance of this, stated with the estimate: 70%); the middle value sits exactly at the limit.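

In this assay, no step can be read between compound 4 and compound 1, compound 2 or compound 3, because all four give a limit rather than a number: the limit of > 150000 nM in this assay, at which 4 of the 4 values shown sit.

The compounds shown leave open how large these steps are and whether any change to the ring attached to the carbonyl gives a measurable value.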